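Methyl for Methoxy on a Pyrimidinyl Thiourea

The source may report more compounds than this note shows. Statements on the series, on what has been measured and on what is new or still open speak of the compounds shown alone.

Compound 1, `Cc1cc(O)nc(NC(=S)NC(=O)c2c(-c3ccc(Cl)cc3Cl)noc2C)n1`: 46.8%
Compound 2, `COc1cc(C)nc2n/c(=N/C(=O)c3c(-c4ccc(Cl)cc4Cl)noc3C)sn12`: 80.5%
Compound 3, `COc1cc(Cl)nc(NC(=S)NC(=O)c2c(-c3ccc(Cl)cc3Cl)noc2C)n1`: 56.3%

In a functional assay on the whole organism (strain L.) for inhibition, with Echinochloa crus-galli as the target, with a stated time of 72 h, tested at 100 mg/L (a lower number here means less inhibition of growth, a higher number more inhibition of growth at the concentration tested), compound 3 stands between its two neighbours. Compound 2 gives 80.5%, a value that lies beyond the scatter above compound 3, while compound 1 gives 46.8% and thus sits within the scatter of compound 3; no ordering of compound 1 and compound 3 is claimed. Compound 2 differs from compound 3 in more than one place, so only its value is compared here.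

Compound 4, `Cc1cc(Cl)nc(NC(=S)NC(=O)c2c(-c3ccc(Cl)cc3Cl)noc2C)n1`, is the next structure. It differs from compound 3 in one place: methyl in place of methoxy on an aromatic carbon. Among the measured compounds shown here, no measured pair isolates exactly this exchange. For the measured compounds named here, the only single-place step available, a number 9.5 percentage points higher from compound 1 to compound 3 (within the scatter), changed both substituents on the same ring at once, and it stayed within the scatter. On that basis the expected step of a number 2.3 percentage points lower from compound 3 to compound 4 (within the scatter) is none beyond the scatter. Compound 4 is therefore estimated at 54%, in a range from 36% to 72%.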

Compound 4, percent growth inhibition at one concentration: 48.7%
Compound 4: the middle estimate sits 5.3 percentage points above what was measured; measured number inside the range.
By their numbers in this assay, from the lowest: compounds 1, 4 and 3 (each within the scatter of the next); then compound 2.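

Read alone for the first time, the change from 4-chloro-6-methoxypyrimidin-2-yl to 4-chloro-6-methylpyrimidin-2-yl gives, in this assay, a number 7.6 percentage points lower from compound 3 to compound 4 (within the scatter), so this exchange on the aromatic carbon shows no change that can be told from the scatter. With the methyl group held constant, chloro in place of hydroxy gives a number 1.9 percentage points higher from compound 1 to compound 4 (within the scatter), and this too is no separable change, so the two substituents that the earlier step altered together are now each seen singly within the scatter. No independent measurement bears on these steps.

The compounds shown leave open whether an amine or a longer chain such as ethoxy on this aromatic carbon would move growth inhibition beyond the scatter. Compound 2 differs from these compounds in more than one place, and its higher value remains tied to no single change.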